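Cyano in place of formyl: a predicted growth-inhibition value

The source may report more compounds than this note shows. Statements on the series, on what has been measured and on what is new or still open speak of the compounds shown alone.

Measured compounds:
compound 1 `CO[C@H]1C[C@H](O[Si](C)(C)C(C)(C)C)O[C@@H](C)/C1=C/CO` — 0.01 ug/mL
compound 2 `CO[C@H]1C[C@H](O[Si](C)(C)C(C)(C)C)O[C@@H](C)/C1=C/C=O` — 0.01 ug/mL
compound 3 `CO/N=C/C=C1\[C@H](C)O[C@@H](O[Si](C)(C)C(C)(C)C)C[C@@H]1OC` — 0.01 ug/mL

In a functional assay on the whole organism for inhibition, with Artemia salina as the target (on this read-out lower numbers stand for stronger inhibition of growth and higher numbers for weaker inhibition of growth), compound 2 gives 0.01 ug/mL, and it stands level with compound 1 and compound 3 at the digits shown; the differences among these three fall within the usual scatter of such measurements. Going by the values given here, the one step between measured compounds, no change at the digits printed from compound 1 to compound 2 (within the scatter), exchanges a hydroxymethyl for a formyl on a double-bonded chain carbon bound to a double-bonded ring carbon, and the read-out does not move beyond the scatter.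

Compound 4 `CO[C@H]1C[C@H](O[Si](C)(C)C(C)(C)C)O[C@@H](C)/C1=C/C#N` has not yet been tested. Its change from compound 2 is cyano in place of formyl on a double-bonded chain carbon bound to a double-bonded ring carbon. Among the compounds with values here, the single measured step at this same place, from compound 1 to compound 2, shows no change, so a further swap of one small two-atom group for another at that spot is expected to leave this assay unchanged beyond the scatter. The expected step is therefore no change at the digits printed from compound 2 to compound 4 (within the scatter), that is, none. For compound 4 the estimate is 0.01 ug/mL, with a likely range from 0.005 ug/mL to 0.02 ug/mL.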

Compound 4, minimum inhibitory concentration: 0.0005 ug/mL
Estimate against measurement, compound 4: 4.3 two-fold dilutions above, and the stated range ends above it.
By their numbers in this assay, from the lowest: compound 4; then compounds 1, 2 and 3 (each within the scatter of the next).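

In this assay, cyano in place of formyl on a double-bonded chain carbon bound to a double-bonded ring carbon gives a number 4.3 two-fold dilutions lower from compound 2 to compound 4 (beyond the scatter), so this position is not indifferent to the group it carries. Cyano in place of hydroxymethyl at the same place gives a number 4.3 two-fold dilutions lower from compound 1 to compound 4 (beyond the scatter), and since formyl and cyano have the same counts of heavy atoms, hydrogen-bond donors and hydrogen-bond acceptors, those counts alone do not predict the result. No measurement shown here accounts for the drop in the number.

On these data alone, it remains open whether a carboxylic acid, an amine or a longer chain ending in cyano at this place would keep the number as low as cyano does. As far as these compounds go, it is also open whether the cyano step would carry over to a core other than the shared one.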